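Same Amino Addition on a Second Core: an Expectation

This account rests on a few compounds, and the source may have more. Where it says the series, first, only, none or still open, it means among the compounds named here.

Of the compounds shown here, three have been tested in a functional assay on HOP-62 cells (Homo sapiens) for cytotoxicity, read by sulforhodamine B assay, with a stated time of 48 h; on this read-out lower numbers stand for stronger inhibition of growth and higher numbers for weaker inhibition of growth. Compound 1 `ClCc1ccc(Cn2cnc3c(Cl)ncnc32)cc1` gives 1940 nM. Compound 2 `Nc1nc(Cl)c2ncn(Cc3ccc(CCl)cc3)c2n1` gives 6920 nM. Compound 3 `ClCc1ccccc1Cn1cnc2c(Cl)ncnc21` gives 2510 nM; this value and that of compound 1 lie within the scatter of each other, whereas compound 2 sits beyond the scatter from both. Compound 4 `Nc1nc(Cl)c2ncn(Cc3ccccc3CCl)c2n1` has not yet been measured in this assay.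

Compound 2 arises from compound 1 by a single change, (amino in place of hydrogen on an aromatic carbon). That change produced a 3.6-fold higher number from compound 1 to compound 2 (0.55 log units; beyond the scatter). Compound 4 arises from compound 3 by the same change, (amino in place of hydrogen on an aromatic carbon), and the description of the place where it occurs matches word for word. Compound 1 and compound 3 contain the same atoms joined differently, but the difference between the two cores is not broken down here.

Only one earlier example of this change exists among these compounds, so the expectation rests on a single step. Because the step of a 3.6-fold higher number from compound 1 to compound 2 (0.55 log units; beyond the scatter) weakened growth inhibition by a modest amount, a step of similar size is expected here. For compound 4 the expected step is a 3.4-fold higher number from compound 3 to compound 4 (0.53 log units; beyond the scatter). The estimate for compound 4 in this assay is 8500 nM, with a likely range from 3500 nM to 20000 nM, kept wide since a single prior step is a thin basis.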

Compound 4, concentration for 50% growth inhibition: 21900 nM
For compound 4 the middle estimate is 2.6-fold (0.41 log units) below the measured one; measured number above the stated range.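

In this assay, putting amino in place of hydrogen on an aromatic carbon weakened growth inhibition again, with an 8.7-fold higher number from compound 3 to compound 4 (0.94 log units; beyond the scatter). Set beside the earlier example, the step points the same way, and its size cannot be told apart from the first: the same change on two cores in this assay, a 3.6-fold higher number (0.55 log units; beyond the scatter) from compound 1 to compound 2 and an 8.7-fold higher number (0.94 log units; beyond the scatter) from compound 3 to compound 4, 2.4-fold (0.39 log units) apart, within the scatter of two such steps. So in this small series the direction of the change carried over from one core to the other, and the two sizes fit a single shared effect, but two steps cannot show that the size is truly constant or that the direction would hold on any further core, and they do not explain why the number rises.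

The compounds shown leave open whether a different group in the same place, between two ring nitrogen atoms, such as a methylamino group, a dimethylamino group or a methoxy group, would raise the number as amino does or leave it unchanged. Going by these compounds, it also remains open whether the chloro group on the same ring matters to the size of the step, as every compound here carries it.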